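The source may report more compounds than this note shows. Statements on the series, on what has been measured and on what is new or still open speak of the compounds shown alone.

Working notes on three esters sharing the core of compound 1 `CCCCCCCCOC(=O)C(O)Cn1cnc2c(N)ncnc21`. In a functional assay on HeLa cells (Homo sapiens) for cytotoxicity (a lower number here means that less compound is tolerated, a higher number that more compound is tolerated), compound 1 gives 100 ug/mL. Compound 2 `CC(C)(C)OC(=O)C(O)Cn1cnc2c(N)ncnc21` reaches only a limit of the assay in this assay, > 400 ug/mL. Among the measured compounds shown here, the single measured step, an at least 4.0-fold higher number from compound 1 to compound 2 (0.60 log units; beyond the scatter), rests on the limit (the limit of > 400 ug/mL in this assay, at which 1 of the 2 values shown sits). Compound 3 `CC(C)CCOC(=O)C(O)Cn1cnc2c(N)ncnc21` differs from compound 2 by isopentyl in place of tert-butyl on an oxygen next to a carbonyl group. The measured step bears on this change in reverse, since isopentyl, like octyl, leaves tert-butyl behind, so a modest fall in the number is expected, partly returning toward compound 1 at 100 ug/mL. Compound 3 is expected to give 200 ug/mL in this assay, between 100 ug/mL and 400 ug/mL. That estimate means the step of an at least 2.0-fold lower number from compound 2 to compound 3 (0.30 log units; that floor lies within the scatter).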

Compound 3, minimum cytotoxic concentration: 400 ug/mL
The estimate for compound 3 lay 2.0-fold (0.30 log units) below the measured number, and the stated range covers the measured number.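

Replacing hexyl with isopropyl on a saturated chain carbon, two bonds along the chain from an oxygen next to a carbonyl group, gives a 4.0-fold higher number from compound 1 to compound 3 (0.60 log units; beyond the scatter) in this assay, so a number well clear of compound 1 does not depend on the tert-butyl group. Compound 2 stands at a limit of the assay, > 400 ug/mL. The size of the step, a number no higher from compound 2 to compound 3 (the limit leaves the size open), cannot be read, so isopentyl and tert-butyl cannot be ranked.

Still open, from the compounds shown here alone, is how the number behaves with a chain between isopentyl and octyl, such as hexyl, and with a longer chain than octyl. Going by these compounds, the effect of a free carboxylic acid in place of the ester is also open.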